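A few compounds are considered here, and "the series" means these few. Any claim that something is new, unique, unknown or untested is made for them only; others in the source may bear on it.

Among the compounds with values here, compound 1 `CCC(C)C(NC(=O)n1nnc2ccccc21)C(=O)NC1CCCCC1` is one of two compounds measured in a functional assay on L1210 cells (Mus musculus) for inhibition; on this read-out lower numbers stand for stronger inhibition and higher numbers for weaker inhibition. In this assay compound 1 gives 109000 nM, the lower of the two numbers shown, though the gap to compound 2 lies within the scatter. Compound 2 `CCC(C)C(NC(=O)n1nnc2ccccc21)C(=O)NCc1ccccc1` in this assay gives 123000 nM; the step of a 1.1-fold higher number from compound 1 to compound 2 (0.05 log units; within the scatter) is a change of benzyl in place of cyclohexyl on an amide-type nitrogen. Compound 3 `CC(C)C(NC(=O)n1nnc2ccccc21)C(=O)NC1CCCCC1` is not yet measured. It differs from compound 1 by hydrogen in place of methyl on a saturated chain carbon, three bonds along the chain from an amide-type nitrogen and a carbonyl carbon. Within the data shown here, no measured step touches that saturated chain carbon; the one recorded step, a 1.1-fold higher number from compound 1 to compound 2 (0.05 log units; within the scatter), concerns a different part of the molecule and stayed within the scatter. With nothing bearing directly on this change and both measured numbers lying close together, compound 3 is expected to give about 110000 nM in this assay, a step of a 1.0-fold higher number from compound 1 to compound 3 (0.00 log units; within the scatter) estimated to fall within the scatter. The expected range for compound 3 runs from 50000 nM to 250000 nM.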

Compound 3, half-maximal inhibitory concentration: 108000 nM
The estimate for compound 3 lay 1.0-fold (0.01 log units) above the measured number; the measured number falls inside the stated range.
By their numbers in this assay, from the lowest: compounds 3, 1 and 2 (each within the scatter of the next).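

In this assay, within the data shown here, the change from sec-butyl to isopropyl, with hydrogen in place of methyl on a saturated chain carbon, gives a first measured step at this position (a 1.0-fold lower number from compound 1 to compound 3 (0.00 log units; within the scatter)), so removing this one carbon from the chain leaves the number within the scatter. Taken with the earlier step on the amide-type nitrogen, this means that neither of the two places changed among these compounds has moved the number beyond the scatter, and the three compounds stay close together. No evidence is available that bears on this result.

The compounds shown leave open whether a longer chain at this position, or a chain carrying an amine or a carboxylic acid, would move the number beyond the scatter. They also leave open whether any change to the shared core would do so.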